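The compounds below may be only part of what the source reports. "The series", "measured", "known", "first", "only" and "open" are said of these compounds alone.

Working notes on the series. The shared core is carried by compound 1 `Nc1ccc(-c2ccc(NC3=CC(=O)c4ncncc4C3=O)cc2)cc1` and by compound 2 `COc1cc(NC2=CC(=O)c3ncncc3C2=O)cc(OC)c1OC`. In a functional assay on MIA PaCa-2 cells (Homo sapiens) for cytotoxicity, read by MTT assay, with a stated time of 72 h (a higher number here means a weaker inhibitor, a lower number a stronger inhibitor), compound 1 gives 2500 nM, and in this assay compound 2 gives 1500 nM. Of the two numbers shown, compound 1 has the higher one; its nearest neighbour is compound 2, and the gap between the two lies within the scatter, so no order between them can be claimed.

Compound 3 `O=C1C(Nc2ccc(Oc3ccccc3)cc2)=CC(=O)c2ncncc21` has not yet been measured in this assay. It differs from compound 1 at one place: phenoxy in place of 4-aminophenyl on an aromatic carbon. The change keeps the ring count and the number of heavy atoms and removes one hydrogen-bond donor; the group sits on an aromatic carbon of a six-membered aromatic ring of carbon only, para to a large group.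

For the measured compounds named here, no step between measured compounds is on record for this kind of change, and only two values exist for the whole series, so the expectation rests on little. The step from compound 1 to compound 3 is expected to be small, in no particular direction, and likely within the scatter: a 1.3-fold lower number from compound 1 to compound 3 (0.10 log units; within the scatter). For compound 3 in this assay the estimate is 2000 nM, with a range from 700 nM to 6000 nM.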

Compound 3, half-maximal inhibitory concentration: 3700 nM
Compound 3: the middle estimate sits 1.9-fold (0.27 log units) below what was measured; measured number inside the range.
By their numbers in this assay, from the lowest: compounds 2, 1 and 3 (each within the scatter of the next, the first and the last beyond it).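

In this assay, for the compounds shown here, phenoxy in place of 4-aminophenyl on an aromatic carbon gives the first step on record at this position: a 1.5-fold higher number from compound 1 to compound 3 (0.17 log units; within the scatter). The exchange keeps the ring count and the number of heavy atoms and loses the hydrogen-bond donor, yet no order between compound 1 and compound 3 can be claimed. The position therefore accepts either group with no change that can be told from the scatter, in this one pair only, and nothing on record bears on what lies behind this result.

A single exchange at this carbon leaves open whether a smaller group such as methoxy, a free amine placed directly on the ring, or a carboxylic acid would give a step beyond the scatter. It also leaves open whether a step of this size would hold on another assay read-out.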